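Anilide in place of acid on two dithioester cores

The compounds below may be only part of what the source reports. "The series", "measured", "known", "first", "only" and "open" are said of these compounds alone.

Compound 1 `CC(=O)SCCC(CCCCC(=O)O)SC(C)=O` is the reference of the first pair. In a functional assay on HO8910 cells (Homo sapiens) for inhibition, read by MTT assay, with a stated time of 24 h, tested at 10 ug/mL (on this read-out lower numbers stand for less inhibition of growth and higher numbers for more inhibition of growth at the one concentration tested), compound 1 gives 1.61%. Compound 3 `CC(=O)SCCC(CCCCC(=O)Nc1ccccc1)SC(C)=O` carries the change (anilino in place of hydroxy on a carbonyl carbon), and the step of a number 1.6 percentage points higher from compound 1 to compound 3 (within the scatter) leaves the two within the scatter of each other; compound 3 gives 3.2%.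

Compound 2 `O=C(O)CCCCC(CCSC(=O)c1ccccc1)SC(=O)c1ccccc1` is the second core. The difference between the two cores is not broken down here. In this assay compound 2 is reported only as "not active" (no number reported), with no number given.

Compound 4 `O=C(CCCCC(CCSC(=O)c1ccccc1)SC(=O)c1ccccc1)Nc1ccccc1` is not yet measured and carries the change (anilino in place of hydroxy on a carbonyl carbon). The two "place" descriptions agree word for word, so this is the same change as in the first pair; it occurs two times among the compounds shown. For compound 4 a step from compound 2 of about the same size as a number 1.6 percentage points higher from compound 1 to compound 3 (within the scatter) is expected, that is, within the scatter.

Since compound 2 gave no number, the expectation for compound 4 rests on the near-zero readings of compound 1 1.61% and compound 3 3.2% as well. Compound 4 is estimated at 3%. The expected range for compound 4 runs from 0% to 12%.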

Compound 4, percent growth inhibition at one concentration: "not active" (no number reported)
No number was reported for compound 4; no gap can be computed for the estimate.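

In this assay, among the compounds shown here, compound 2 and compound 4 are both reported without a number, so no step between them can be read. Nothing shown here bears on these readings. The compounds shown leave open whether anilino in place of hydroxy changes growth inhibition on the core of compound 2.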